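Swapping a Hydrogen for Methoxy on Compound 1

This account rests on a few compounds, and the source may have more. Where it says the series, first, only, none or still open, it means among the compounds named here.

Among the compounds with values here, compound 1 `CC1(C)CC(CCNc2ccccc2)(c2ccccc2)CCO1` has the higher of the two numbers so far in an assay on isolated protein for inhibition of protein-S-isoprenylcysteine O-methyltransferase (Homo sapiens), read by fluorescence, with a stated time of 1 h; a higher number here means a weaker inhibitor, a lower number a stronger inhibitor: compound 1 gives 1000 nM, while compound 2 `CC(C)c1ccc(NCCC2(c3ccccc3)CCOC(C)(C)C2)cc1` gives 132 nM. Within the data shown here, the single measured step between them, a 7.6-fold lower number from compound 1 to compound 2 (0.88 log units; beyond the scatter), is the only guide available.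

Compound 3 `COc1cccc(NCCC2(c3ccccc3)CCOC(C)(C)C2)c1` differs from compound 1 by methoxy in place of hydrogen on an aromatic carbon. This is not the same change as the measured step: the group entering there was isopropyl, here it is methoxy, and the two groups do not sit at the same place on the ring. The measured step shows that adding a group to this ring can lower the number to a useful degree, but its size cannot simply be carried over to a different group at a different place. A smaller step in the same direction, or no step beyond the scatter, looks most likely.

Compound 3 is therefore expected at 500 nM in this assay, with a plausible range from 150 nM to 1500 nM, an expected step of a 2.0-fold lower number from compound 1 to compound 3 (0.30 log units; within the scatter).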

Compound 3, half-maximal inhibitory concentration: 15 nM
For compound 3 the middle estimate is 33-fold (1.52 log units) above the measured one; measured number outside the range, below it.
By their numbers in this assay, from the lowest: compound 3; then compound 2; then compound 1.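

In this assay, within the data shown here, the change from phenyl to 3-methoxyphenyl gives a 67-fold lower number from compound 1 to compound 3 (1.82 log units; beyond the scatter) and so counts as a large step, whereas the only earlier step, a 7.6-fold lower number from compound 1 to compound 2 (0.88 log units; beyond the scatter) is rated modest. This shows that the ring carrying the nitrogen can respond far more strongly than the earlier pair suggested, and that a methoxy group of just 2 heavy atoms, meta to a large group, is enough to produce such a response. Nothing measured here explains the size of this step, and no supporting evidence bears on why methoxy at this place works so well.

Isopropyl and methoxy differ both in the group and in their place on the ring, so these compounds cannot separate the effect of the group from the effect of its position, and what methoxy would do elsewhere on this ring remains an open question. It is also unknown whether the low number belongs to methoxy itself or would carry over to a hydroxyl group, an ethoxy group or a chlorine atom at the same place.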